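The source may report more compounds than this note shows. Statements on the series, on what has been measured and on what is new or still open speak of the compounds shown alone.

Measured compounds in an ADME assay on HEK293 cells (Homo sapiens) for cytotoxicity, read by MTT assay, with a stated time of 48 h; a lower number here means a stronger inhibitor, a higher number a weaker inhibitor:

compound 1 `CS(=O)(=O)Nc1ccc(NC(=O)c2ccc(Cl)cc2)cc1Cl`: 167000 nM
compound 2 `CS(=O)(=O)Nc1ccc(NC(=O)c2cccc(C(F)(F)F)c2)cc1Cl`: > 250000 nM
compound 3 `CS(=O)(=O)Nc1ccc(NC(=O)c2ccc(Cl)cc2)cc1F`: 216000 nM

Compound 1 and compound 2 share an amide-linked sulfonamide scaffold, but the difference between their two cores is not broken down here. For compound 2 the reading is only (the limit of > 250000 nM in this assay, at which 1 of the 3 values shown sits), so it is a limit of the assay and not a number.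

Compound 3 arises from compound 1 by one change, (fluoro in place of chloro on an aromatic carbon). In this assay that change gives a 1.3-fold higher number from compound 1 to compound 3 (0.11 log units; within the scatter), so the two values are indistinguishable in practice.

Compound 4 `CS(=O)(=O)Nc1ccc(NC(=O)c2cccc(C(F)(F)F)c2)cc1F`, not yet measured, arises from compound 2 by the same change, (fluoro in place of chloro on an aromatic carbon); the surroundings of the exchanged atom are the same in both pairs. From compound 2 to compound 4 the step is expected to be a step that the limit leaves unreadable from compound 2 to compound 4, resting on compound 1 to compound 3 giving a 1.3-fold higher number from compound 1 to compound 3 (0.11 log units; within the scatter). Compound 4 is therefore estimated at 300000 nM, most likely again beyond the reach of this assay, within 150000 nM to 600000 nM.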

Compound 4, half-maximal inhibitory concentration: > 250000 nM
Compound 4 ended at the assay's limit (the forecaster's own chance of this, stated with the estimate: 70%); the middle value is on the limit's open side.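

Compound 2 and compound 4 both read as limits in this assay, not as numbers, so the step between them, fluoro in place of chloro, cannot be read: the limit of > 250000 nM in this assay, at which 2 of the 4 values shown sit. On these data alone, how far past that limit each compound lies, and whether this exchange changes anything in these two compounds, stays open.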